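The source may hold more compounds than are shown below. What is called first, only, known or untested is meant among the compounds shown, and "the series" means these compounds.

Three compounds share one core and differ only in the group at its far end. In a physicochemical assay for lipophilicity, read by HPLC, at pH 7.5 (a lower number here means a more polar compound, a higher number a more lipophilic compound), compound 1 `CC[C@@H](Nc1c(C#N)c(-c2ccc(-c3ccccc3NC)cc2)nc2cnccc12)C(N)=O` gives 2.5. Compound 2 `CC[C@@H](Nc1c(C#N)c(-c2ccc(-c3cccc(CO)c3)cc2)nc2cnccc12)C(N)=O` gives 2, and compound 3 `CC[C@@H](Nc1c(C#N)c(-c2ccc(-c3ccccc3N(C)C)cc2)nc2cnccc12)C(N)=O` gives 3.2, the highest of the three: a number 0.70 log units higher from compound 1 to compound 3 (beyond the scatter), and a number 1.20 log units higher from compound 2 to compound 3 (beyond the scatter). Compound 4 `CC[C@@H](Nc1c(C#N)c(-c2ccc(-c3ccccc3Cl)cc2)nc2cnccc12)C(N)=O` differs from compound 3 in one place: chloro in place of dimethylamino on an aromatic carbon. Among the measured compounds shown here, no measured step exchanges dimethylamino for chloro, and the steps of a number 0.50 log units lower from compound 1 to compound 2 (beyond the scatter) and a number 1.20 log units higher from compound 2 to compound 3 (beyond the scatter) concern other groups, so they give only a sense of how far such a swap can move the number. From compound 3 the step of no change at the digits printed from compound 3 to compound 4 (within the scatter) is expected to stay within the scatter. Compound 4 is estimated at 3.2, between 2.7 and 3.7.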

Compound 4, distribution coefficient: 2.9
Compound 4: the middle estimate sits 0.30 log units above what was measured; measured number inside the range.
By their numbers in this assay, from the lowest: compound 2; then compound 1; then compounds 4 and 3 (each within the scatter of the next).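

In this assay, chloro on this aromatic carbon, ortho to a large group, reads much like dimethylamino (a number 0.30 log units lower from compound 3 to compound 4 (within the scatter)), so a single heavy atom here does about as much as three. Compound 4 still stands clear of the other two compounds (a number 0.40 log units higher from compound 1 to compound 4 (beyond the scatter); a number 0.90 log units higher from compound 2 to compound 4 (beyond the scatter)). Nothing at hand gives a reason for these numbers. On these data alone, what a methoxy group or a carboxylic acid would read in this place stays open, as does whether chloro would read the same on a different core.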